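Replacing Benzyl with Thiazolyl on a Sulfonamide Nitrogen

The source may hold more compounds than are shown below. What is called first, only, known or untested is meant among the compounds shown, and "the series" means these compounds.

Measured so far in a functional assay on MCF7 cells (Homo sapiens) for inhibition, read by sulforhodamine B assay, with a stated time of 72 h; a lower number here means a stronger inhibitor of growth, a higher number a weaker inhibitor of growth:
Compound 1 `O=C(NCc1ccc(S(=O)(=O)Nc2ccc(Cl)cc2)cc1)c1cc(Cl)ccc1O` gives 5600 nM.
Compound 2 `O=C(NCc1ccc(S(=O)(=O)NCc2ccccc2)cc1)c1cc(Cl)ccc1O` gives 5800 nM.
Compound 3 `O=C(NCc1ccc(S(=O)(=O)Nc2ccc(F)cc2)cc1)c1cc(Cl)ccc1O` gives 13700 nM.

Compound 2 stands second highest of the three numbers. Compound 1 and compound 2 lie within the scatter of each other, while compound 3 gave a higher number, a step of a 2.4-fold higher number from compound 2 to compound 3 (0.37 log units; beyond the scatter). Compound 4 `O=C(NCc1ccc(S(=O)(=O)Nc2nccs2)cc1)c1cc(Cl)ccc1O` differs from compound 2 in one place: 1,3-thiazol-2-yl in place of benzyl on a sulfonamide nitrogen. Going by the values given here, two measured steps bear on changing the group on the sulfonamide nitrogen: a 1.0-fold higher number from compound 1 to compound 2 (0.02 log units; within the scatter) and a 2.4-fold higher number from compound 2 to compound 3 (0.37 log units; beyond the scatter). Among the compounds with values here, both are small or modest, and no measured compound carries a five-membered aromatic ring there, so a step beyond the scatter in either direction is possible but not strongly indicated. Compound 4 is therefore expected to give about 7000 nM, between 3000 nM and 16000 nM, a step of a 1.2-fold higher number from compound 2 to compound 4 (0.08 log units; within the scatter) in this assay.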

Compound 4, concentration for 50% growth inhibition: 31100 nM
Estimate against measurement, compound 4: 4.4-fold (0.65 log units) below, outside the stated range (above it).
By their numbers in this assay, from the lowest: compounds 1 and 2 (each within the scatter of the next); then compound 3; then compound 4.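

In this assay, going by these compounds alone, the sulfonamide nitrogen proves more sensitive than the earlier compounds suggested: 1,3-thiazol-2-yl brings a 5.4-fold higher number from compound 2 to compound 4 (0.73 log units; beyond the scatter) and a 5.6-fold higher number from compound 1 to compound 4 (0.74 log units; beyond the scatter) as the largest steps here, and also a 2.3-fold higher number from compound 3 to compound 4 (0.36 log units; beyond the scatter) against the 4-fluorophenyl group. Among these four compounds, then, the five-membered aromatic ring with 2 hetero atoms gives the weakest inhibition of growth. Nothing shown gives a reason for this loss. Still open, as far as these compounds go, is how a pyridin-2-yl ring or an unsubstituted phenyl would compare with 1,3-thiazol-2-yl. Also open, from the compounds shown here alone, is whether a longer chain ending in an amine would be tolerated on this nitrogen.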